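This account rests on a few compounds, and the source may have more. Where it says the series, first, only, none or still open, it means among the compounds named here.

Three compounds share one core and differ only in the group attached to a saturated chain carbon bound to a nitrogen on an aromatic ring. Compound 1 `Brc1cccc(Br)c1N(CC1CC1)C1=NCCN1` carries a cyclopropyl there, compound 2 `CCCCCN(C1=NCCN1)c1c(Br)cccc1Br` a butyl, and compound 3 `Brc1cccc(Br)c1N(CC1CCC1)C1=NCCN1` a cyclobutyl. In a physicochemical assay for lipophilicity (a lower number here means a more polar compound, a higher number a more lipophilic compound), compound 1 gives -1.12, compound 2 gives 0.32, and compound 3 gives -0.06. Compound 2 therefore stands highest of the three: compound 3 is nearest, with a step of a number 0.38 log units lower from compound 2 to compound 3 (beyond the scatter), and compound 1 is furthest, with a step of a number 1.44 log units higher from compound 1 to compound 2 (beyond the scatter).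

Compound 4 `Brc1cccc(Br)c1N(CC1CCCC1)C1=NCCN1` is not yet measured in this assay. It differs from compound 2 in one place: cyclopentyl in place of butyl on a saturated chain carbon bound to a nitrogen on an aromatic ring.

Within the data shown here, two measured steps bear on this change. The step of a number 0.38 log units lower from compound 2 to compound 3 (beyond the scatter) shows what closing the butyl into a four-membered ring did, and the step of a number 1.06 log units higher from compound 1 to compound 3 (beyond the scatter) shows what one more ring carbon did. A cyclopentyl is one carbon larger than the cyclobutyl of compound 3, so the expectation for compound 4 is a number above that of compound 3 and modestly above that of compound 2, a step of a number 0.28 log units higher from compound 2 to compound 4 (within the scatter). Compound 4 is estimated at 0.6, within a range from 0.1 to 1.1.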

Compound 4, distribution coefficient: 0.32
Compound 4: middle estimate off by 0.28 log units, on the high side; the measured number falls inside the stated range.
By their numbers in this assay, from the lowest: compound 1; then compound 3; then compounds 2 and 4 (each within the scatter of the next).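

In this assay the three rings now form a short series, and the step of a number 0.38 log units higher from compound 3 to compound 4 (beyond the scatter) runs in the same direction as the step of a number 1.06 log units higher from compound 1 to compound 3 (beyond the scatter), giving a total step a number 1.44 log units higher from compound 1 to compound 4 (beyond the scatter) across the series. The comparison with the open chain also changes: cyclopropyl and cyclobutyl both give lower numbers than butyl, but compound 4 goes against that pattern, with no change at the digits printed from compound 2 to compound 4 (within the scatter), so carrying a ring does not by itself set a compound below the butyl compound at this position. No available measurement explains these steps or why cyclopentyl, with one more carbon than butyl, matches it at the digits printed.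

The compounds shown leave open whether a cyclohexyl would continue the rise seen across the three rings or whether the numbers would level off, and how a longer chain such as hexyl would compare with it. They also leave open how the number would respond to an amine or an ether oxygen built into this group.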